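The compounds below may be only part of what the source reports. "The series", "measured", "known", "first", "only" and "open" are said of these compounds alone.

Of the compounds shown here, three built on one shared core have been measured in an in vitro functional assay on HEK293-A cells for positive allosteric modulation of metabotropic glutamate receptor 5 (Homo sapiens), read by FLIPR and calcium flux; on this read-out lower numbers stand for an effect already at smaller amounts and higher numbers for an effect only at larger amounts of compound. Compound 1 `O=C1CC(c2nc(-c3cccc(Cl)c3)no2)CN1c1ccc(Cl)cc1` gives 140 nM. Compound 2 `O=C1CC(c2nc(-c3cccc(Cl)c3)no2)CN1c1ccc(Cl)c(Cl)c1` gives 460 nM, the second highest of the three numbers, with compound 1 as its nearest neighbour and compound 3 as the furthest. Compound 3 `Cc1ccc(N2CC(c3nc(-c4cccc(C(F)(F)F)c4)no3)CC2=O)cc1` gives 3400 nM. Within the data shown here, the only single-place change among the measured compounds is the one from compound 1 to compound 2, a chloro in place of hydrogen on an aromatic carbon, which brought a 3.3-fold higher number from compound 1 to compound 2 (0.52 log units; beyond the scatter).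

Compound 4 `O=C1CC(c2nc(-c3ccc(Cl)cc3)no2)CN1c1ccc(Cl)c(Cl)c1` has the same atoms as compound 2, joined differently: 4-chlorophenyl in place of 3-chlorophenyl on an aromatic carbon. Among the measured compounds shown here, no measured step bears on this kind of change. For the measured compounds named here, the step of a 3.3-fold higher number from compound 1 to compound 2 (0.52 log units; beyond the scatter) concerns a chlorine added on the other aromatic ring, not a chlorine moved within the ring attached to the five-membered ring, and compound 3 differs from the others in two places at once, so it offers no single step either. The direction of the step is therefore open, and the expectation must be wide. Compound 4 is estimated to give 800 nM, within a range from 200 nM to 3500 nM. The step from compound 2 to compound 4 is expected to be a 1.7-fold higher number from compound 2 to compound 4 (0.24 log units; within the scatter).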

Compound 4, half-maximal effective concentration: 1100 nM
For compound 4 the middle estimate is 1.4-fold (0.14 log units) below the measured one, within the range that was stated.
By their numbers in this assay, from the lowest: compound 1; then compound 2; then compound 4; then compound 3.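

Keeping every atom of compound 2 and only shifting the chlorine, from 3-chlorophenyl to 4-chlorophenyl, on the aromatic carbon of the five-membered aromatic ring brings in this assay a 2.4-fold higher number from compound 2 to compound 4 (0.38 log units; beyond the scatter) and so moves the result past the usual scatter of repeated measurements. The earlier compounds shown here showed only that adding a chlorine to the other aromatic ring changes the number, whereas this pair shows that at this position the place of a chlorine on the phenyl group matters even when the composition stays the same. In this pair the 3-chlorophenyl group gives the lower number, though the size of the change is modest and it rests on a single comparison, made with the rest of compound 2 held fixed. Nothing available here explains why the shift of the chlorine has this effect.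

On these data alone, whether the same shift would give a similar change with the single chlorine on the other ring, as in compound 1, stays open. As far as these compounds go, it is also open how this position would respond if the phenyl group carried a methoxy group, a nitrile or an amine in place of the chlorine.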